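A few compounds are considered here, and "the series" means these few. Any claim that something is new, unique, unknown or untested is made for them only; others in the source may bear on it.

In a functional assay on MCF7 cells (Homo sapiens) for antiproliferative activity, read by MTT assay, with a stated time of 72 h (a higher number here means a weaker inhibitor, a lower number a stronger inhibitor), compound 3, `O=c1cc(CSC(=S)N2CCCCC2)oc2ccccc12`, sits at the limit of the assay, > 25000 nM. Compound 2, `O=c1cc(CSC(=S)N2CCCC2)oc2ccccc12`, gives 35800 nM. The step that the limit leaves unreadable from compound 2 to compound 3 is one that the limit leaves unreadable. Compound 1, `COc1ccc2oc(CSC(=S)N3CCOCC3)cc(=O)c2c1`, also sits at the limit, giving > 25000 nM. With the limit of > 25000 nM in this assay, at which 2 of the 3 values shown sit, the numbers shown contain no readable step at all. Compound 4, `COc1ccc2oc(CSC(=S)N3CCCCC3)cc(=O)c2c1`, differs from compound 3 by methoxy in place of hydrogen on an aromatic carbon. No measured step among these compounds bears on that exchange, and the single step shown, pyrrolidinyl to piperidinyl, is itself unreadable. Compound 4 is therefore expected to remain near the limit, with the step that the limit leaves unreadable from compound 3 to compound 4 expected not to go beyond the scatter. Compound 4 is estimated at 40000 nM, between 20000 nM and 100000 nM.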

Compound 4, half-maximal inhibitory concentration: 10000 nM
Compound 4: the middle estimate sits 4.0-fold (0.60 log units) above what was measured; measured number below the stated range.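

In this assay, among the compounds shown here, methoxy in place of hydrogen on an aromatic carbon gives an at least 2.5-fold lower number from compound 3 to compound 4 (0.39 log units; beyond the scatter), so this position, which no earlier readable step touched, bears on the read-out. With methoxy present, the group on the thiocarbonyl carbon also matters: piperidin-1-yl in place of morpholin-4-yl gives an at least 2.5-fold lower number from compound 1 to compound 4 (0.39 log units; beyond the scatter). Both steps start from a limit, so their true size stays unknown: the limit of > 25000 nM in this assay, at which 2 of the 4 values shown sit.

On these data alone, whether a hydroxyl, a chlorine or an ethoxy group at this position would do the same remains open. So does the effect of methoxy when pyrrolidin-1-yl sits on the thiocarbonyl carbon.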